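The compounds below may be only part of what the source reports. "The series", "measured", "known", "first", "only" and "open" are said of these compounds alone.

Measured compounds:
compound 1 `CC(C)(C)OC(=O)NCC#Cc1ccc2c(c1)C=C([N+](=O)[O-])C(C(F)(F)F)O2`, 1200 nM
compound 2 `CC[Si](C#Cc1ccc2c(c1)C=C([N+](=O)[O-])C(C(F)(F)F)O2)(CC)CC`, 604 nM
compound 3 `O=[N+]([O-])C1=Cc2cc(C#CC3CC3)ccc2OC1C(F)(F)F`, 4870 nM

In a functional assay on 1321N1 cells for antagonist activity at P2Y purinoceptor 6 (Homo sapiens), read by fluorescence and calcium flux (on this read-out higher numbers stand for weaker inhibition and lower numbers for stronger inhibition), compound 1 gives 1200 nM, the second highest of the three numbers. Compound 2 gives 604 nM, and a 2.0-fold lower number from compound 1 to compound 2 (0.30 log units; within the scatter). Compound 3 gives 4870 nM, and a 4.1-fold higher number from compound 1 to compound 3 (0.61 log units; beyond the scatter), while an 8.1-fold higher number from compound 2 to compound 3 (0.91 log units; beyond the scatter).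

Compound 4 `O=C(O)CCCC(=O)NCC#Cc1ccc2c(c1)C=C([N+](=O)[O-])C(C(F)(F)F)O2` keeps the shared core and differs from compound 1 only on the carbonyl carbon of the side chain: 3-carboxypropyl in place of tert-butoxy on a carbonyl carbon. For the measured compounds named here, none of the measured steps touches this carbonyl carbon; all three change the whole group on the triple-bonded carbon. Going by the values given here, they show only that the two longer groups, in compound 1 and compound 2, sit within the scatter of each other, and that the small cyclopropyl of compound 3 gives a modestly higher number. Compound 4 keeps a group of similar length, so the step in this assay is expected to be small, with a slight lean toward a higher number. Compound 4 is therefore estimated at 1800 nM, in a range from 600 nM to 5500 nM, which means an expected step of a 1.5-fold higher number from compound 1 to compound 4 (0.18 log units; within the scatter).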

Compound 4, half-maximal inhibitory concentration: 69100 nM
Compound 4: middle estimate off by 38-fold (1.58 log units), on the low side; the whole stated range lies below it.
By their numbers in this assay, from the lowest: compounds 2 and 1 (each within the scatter of the next); then compound 3; then compound 4.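

The steps among compound 1, compound 2 and compound 3 all replaced the whole group on the triple-bonded carbon, whereas this change sits further out, on a carbonyl carbon whose other neighbour is an amide-type nitrogen. In this assay, putting 3-carboxypropyl in place of tert-butoxy gives a 58-fold higher number from compound 1 to compound 4 (1.76 log units; beyond the scatter), a large step, even though the groups are close in size, so this part of the side chain is far from indifferent to what it carries. Nothing shown here explains the size of this step.

Going by these compounds, what remains open is which feature of 3-carboxypropyl matters. A methyl ester in place of its carboxylic acid, a plain alkyl chain, or an amine at the chain end could help separate the acid from the chain that carries it.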